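The source may hold more compounds than are shown below. What is called first, only, known or untested is meant among the compounds shown, and "the series" means these compounds.

Measured compounds:
- compound 1, `CC(=O)c1cc(-c2ccccc2)cc2cc(-c3ccccc3)[nH]c12`, 72.3%
- compound 2, `COc1ccc(-c2cc(C(C)=O)c3[nH]c(-c4ccccc4)cc3c2)cc1`, 87.9%
- compound 3, `CC(=O)c1cc(-c2ccccc2)cc2cc(-c3ccc(F)cc3)[nH]c12`, 91.1%

The three compounds share one core and were read in a functional assay on HeLa cells (Homo sapiens) for cytotoxicity, read by MTT assay, with a stated time of 2 days, tested at 0.1 uM; on this read-out lower numbers stand for a stronger effect and higher numbers for a weaker effect at the one concentration tested. Compound 3 holds the highest of the three numbers, but its neighbour is compound 2, whose value lies within the scatter of it, so no order between compound 3 and compound 2 can be claimed. The furthest of the three is compound 1, and the step of a number 18.8 percentage points higher from compound 1 to compound 3 (beyond the scatter) lies beyond the scatter.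

The next compound is compound 4, `COc1ccc(-c2cc(C(C)=O)c3[nH]c(-c4ccc(F)cc4)cc3c2)cc1`. It differs from compound 3 in one place: methoxy in place of hydrogen on an aromatic carbon.

The same change has been seen once, on compound 1: the step of a number 15.6 percentage points higher from compound 1 to compound 2 (beyond the scatter) was modest and pointed to a weaker effect. That change was made on the other aryl ring of the core, and the step of a number 18.8 percentage points higher from compound 1 to compound 3 (beyond the scatter) showed fluoro acting in the same direction. Both steps suggest that the number for compound 4 is expected to move upward again in this assay, or to stay within the scatter, since compound 3 already stands close to the top of the scale and little room is left above it. The estimated step of a number 3.9 percentage points higher from compound 3 to compound 4 (within the scatter) is therefore expected to be small.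

Compound 4 is estimated at 95%, with a range from 84% to 104%.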

Compound 4, a percentage reported as activity, at one concentration (the size of the read-out at that concentration, not a potency): 74.5%
Compound 4: the middle estimate sits 20.5 percentage points above what was measured; the whole stated range lies above it.
By their numbers in this assay, from the lowest: compounds 1 and 4 (each within the scatter of the next); then compounds 2 and 3 (each within the scatter of the next).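

With fluoro already on the core, the change from phenyl to 4-methoxyphenyl in this assay gives a number 16.6 percentage points lower from compound 3 to compound 4 (beyond the scatter), so on these compounds the sign of this change depends on the rest of the molecule: the same change on two cores in this assay, a number 15.6 percentage points higher (beyond the scatter) from compound 1 to compound 2 and a number 16.6 percentage points lower (beyond the scatter) from compound 3 to compound 4, 32.2 percentage points apart, beyond the scatter of two such steps

The fluoro change shows the same dependence, now read with methoxy already in place, where it gives a number 13.4 percentage points lower from compound 2 to compound 4 (beyond the scatter): the same change on two cores in this assay, a number 18.8 percentage points higher (beyond the scatter) from compound 1 to compound 3 and a number 13.4 percentage points lower (beyond the scatter) from compound 2 to compound 4, 32.2 percentage points apart, beyond the scatter of two such steps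

Neither group can therefore be given a single step of its own in this series, and the two steps that end at compound 4 show that the changes do not simply add on the shared core.

Going by these compounds, four compounds form only one such square, so it remains open whether the reversal belongs to methoxy and fluoro alone or would also appear with an amine or a carboxylic acid at the same place on the ring. A single concentration also leaves open whether the same reversal would hold across a range of concentrations, and these data give no potency for any of the compounds.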